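This account rests on a few compounds, and the source may have more. Where it says the series, first, only, none or still open, it means among the compounds named here.

Measured in a functional assay on CHO cells with adenosine receptor A1 (Homo sapiens) as the target, read by cAMP accumulation and immunoassay, with a stated time of 6 min, tested at 0.01 uM; on this read-out lower numbers stand for a stronger effect and higher numbers for a weaker effect at the one concentration tested:
compound 1 `Nc1scc(CN2CCN(c3cc(Cl)cc(Cl)c3)CC2)c1C(=O)c1ccc(Cl)cc1` gives -1%
compound 2 `Nc1scc(CN2CCN(c3cc(F)cc(F)c3)CC2)c1C(=O)c1ccc(Cl)cc1` gives -13%

Compound 2 holds the lowest of the two numbers; its nearest neighbour is compound 1, separated by a number 12 percentage points lower from compound 1 to compound 2 (beyond the scatter). Compound 3 `Nc1scc(CN2CCN(c3ccccc3Cl)CC2)c1C(=O)c1ccc(Cl)cc1` is not yet measured; its difference from compound 2 is 2-chlorophenyl in place of 3,5-difluorophenyl on an amine nitrogen in a ring. Among the measured compounds shown here, the only measured step, a number 12 percentage points lower from compound 1 to compound 2 (beyond the scatter), also exchanges the halogens of the group on an amine nitrogen in a ring, but here the halogen count and pattern change together, so that step bears only loosely. A step of a number 8 percentage points higher from compound 2 to compound 3 (within the scatter) is expected, within the scatter, drifting back toward compound 1 at -1%. Compound 3 is estimated at -5%, range -25% to 15%.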

Compound 3, a percentage reported as activity, at one concentration (the size of the read-out at that concentration, not a potency): -2.1%
Beside the measured number, compound 3's estimate is 2.9 percentage points below it, and the stated range covers the measured number.
By their numbers in this assay, from the lowest: compound 2; then compounds 3 and 1 (each within the scatter of the next).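

In this assay, 2-chlorophenyl in place of 3,5-difluorophenyl gives a number 10.9 percentage points higher from compound 2 to compound 3 (beyond the scatter), while 2-chlorophenyl in place of 3,5-dichlorophenyl gives a number 1.1 percentage points lower from compound 1 to compound 3 (within the scatter). The two chlorophenyl groups are therefore not told apart at this position on the ring amine nitrogen, and of the three groups only 3,5-difluorophenyl stands apart. Nothing available explains this difference. Left open is whether 2-fluorophenyl would read with compound 2 or with compound 1 and compound 3, and what a methoxy group or an amine on the phenyl ring would give.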